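The compounds below may be only part of what the source reports. "The series", "measured", "known", "first", "only" and "open" are said of these compounds alone.

Among the compounds with values here, in a physicochemical assay for solubility, read by HPLC, at pH 7.4 (on this read-out higher numbers stand for higher solubility and lower numbers for lower solubility), compound 1 (`COCc1cc(N)c(Nc2ccc(C#N)cc2)cc1Oc1c(C)cc(/C=C/C#N)cc1C`) gives 0.11 ug/mL, and compound 2 (`CC(=O)OCc1cc(N)c(Nc2ccc(C#N)cc2)cc1Oc1c(C)cc(/C=C/C#N)cc1C`) gives 0.49 ug/mL, the higher of the two numbers so far. Compound 3 (`CC(=O)OCc1cc(N)c(Nc2ccc(C#N)cc2)cc1Oc1c(C)cc(CCC#N)cc1C`) keeps the acetyl of compound 2 and differs from it elsewhere, with 2-cyanoethyl in place of 2-cyanoethenyl on an aromatic carbon. Within the data shown here, only one measured step is available, and it lies at another place: acetyl in place of methyl on an oxygen on a saturated carbon, which gave a 4.5-fold higher number from compound 1 to compound 2 (0.65 log units; beyond the scatter). That modest step shows how far a single change has moved the numbers in this series, but it says nothing directly about the 2-cyanoethenyl group. Among the measured compounds shown here, no measured compound carries a change at that group, so the direction remains open. In this assay, no shift beyond the usual scatter is therefore expected, with only a slight lean upward. The expected change is a 1.3-fold higher number from compound 2 to compound 3 (0.12 log units; within the scatter). The estimated value for compound 3 is 0.65 ug/mL, with an expected range of 0.22 ug/mL to 1.9 ug/mL.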

Compound 3, solubility: 1.86 ug/mL
Compound 3: middle estimate off by 2.9-fold (0.46 log units), on the low side; measured number inside the range.
By their numbers in this assay, from the lowest: compound 1; then compound 2; then compound 3.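

In this assay, replacing 2-cyanoethenyl with 2-cyanoethyl on an aromatic carbon, meta to two methyl groups and para to a large group, gives a 3.8-fold higher number from compound 2 to compound 3 (0.58 log units; beyond the scatter) and so shows that the number responds beyond the usual scatter to a change at this position, which the step between compound 1 and compound 2 left untouched. The two groups match in heavy atoms, nitrile triple bond, hydrogen-bond donors and hydrogen-bond acceptors, so the step goes with the loss of the one double bond outside the aromatic rings, the only counted difference between them. No measurement shown here bears on why the number rises with this change.

From the compounds shown here alone, it remains open whether a longer chain, an amine or a carboxylic acid on this aromatic carbon would carry the number further or bring it back. Also open, going by these compounds, is whether 2-cyanoethyl in place of 2-cyanoethenyl gives a step of similar size when the methyl of compound 1 stands where compound 2 has its acetyl.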